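This account rests on a few compounds, and the source may have more. Where it says the series, first, only, none or still open, it means among the compounds named here.

Measured so far:
compound 1 `COc1cc2c(/C=C3/C(=O)Nc4ccc(O)cc43)c(Cl)n(Cc3cc(OC)c(OC)c(OC)c3)c2cc1C` — 1450 nM
compound 2 `O=C1Nc2ccccc2/C1=C\c1c(Cl)n(Cc2ccccc2)c2ccccc12` — 8910 nM

In a functional assay on cells (Melanoma cell, Homo sapiens) for cytotoxicity, with a stated time of 48 h (a higher number here means a weaker inhibitor of growth, a lower number a stronger inhibitor of growth), compound 1 gives 1450 nM, the lower of the two numbers; compound 2 gives 8910 nM, a gap beyond the scatter. Among the measured compounds shown here, the two differ in several places at once, so no single step is isolated between them.

Compound 3 `COc1cc2c(/C=C3/C(=O)Nc4ccc(Cl)cc43)c(Cl)n(Cc3cc(OC)c(OC)c(OC)c3)c2cc1C` is not yet measured. It differs from compound 1 by chloro in place of hydroxy on an aromatic carbon, on the aromatic carbon of the six-membered ring within the fused two-ring system. For the measured compounds named here, with no comparable step among the measured compounds, the direction is open; a change within or just beyond the scatter is expected, a 1.4-fold higher number from compound 1 to compound 3 (0.14 log units; within the scatter). Compound 3 is estimated at 2000 nM, range 700 nM to 6000 nM.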

Compound 3, concentration for 50% growth inhibition: 2290 nM
For compound 3 the middle estimate is 1.1-fold (0.06 log units) below the measured one; low and high end bracket the measured number.
By their numbers in this assay, from the lowest: compounds 1 and 3 (each within the scatter of the next); then compound 2.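

In this assay, chloro in place of hydroxy on this aromatic carbon, meta to a fused ring and para to a fused ring, gives a 1.6-fold higher number from compound 1 to compound 3 (0.20 log units; within the scatter) and so stays within the scatter. At this position, on the core of compound 1, a hydroxy group with its hydrogen-bond donor and a chloro group with none therefore read alike. The earlier compounds shown here isolated no single step and could not show this.

As far as these compounds go, whether an amine or a carboxylic acid on this carbon would read the same remains open. No measurement here accounts for the two groups reading alike.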